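A few compounds are considered here, and "the series" means these few. Any claim that something is new, unique, unknown or untested is made for them only; others in the source may bear on it.

Measured compounds in an assay on V79 cells for inhibition of cytochrome P450 11B2, mitochondrial (Homo sapiens), read by HTRF, with a stated time of 1 h; a higher number here means a weaker inhibitor, a lower number a stronger inhibitor:

Compound 1, `FC(F)(F)c1ccc2c(c1)nc(-c1cccnc1)n2C1CC1`: > 10000 nM, a limit of the assay rather than a number.
Compound 2, `Cn1c(-c2cccnc2)nc2ccc(F)cc21`: 12 nM.
Compound 3, `Cc1ccncc1-c1nc2cc(F)c(F)cc2n1C1CC1`: 10.2 nM.

Among the measured compounds shown here, compound 1 sits at the limit of > 10000 nM in this assay, at which 1 of the 3 values shown sits, so only a bound is known for it, and it is the one compound of the three that gives no number in this assay. Compound 2 and compound 3 both give numbers in this assay and lie within the usual scatter of each other, so no order between them is claimed.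

Compound 4, `c1cncc(-c2nc3ccccc3n2C2CC2)c1`, has not been measured in this assay. It differs from compound 1 by hydrogen in place of trifluoromethyl on an aromatic carbon, with the rest of the shared core, the pyridine and the cyclopropyl kept as in compound 1.

Compound 4 shares the cyclopropyl group and the shared core with compound 3, which gives 10.2 nM in this assay, and compound 2 shows that the shared core without the cyclopropyl gives 12 nM. On that basis the step from compound 1 to compound 4 is expected to be large and toward stronger inhibition, an at least 100-fold lower number from compound 1 to compound 4 (2.00 log units; beyond the scatter). Compound 4 is therefore estimated at 100 nM in this assay, within a range of 15 nM to 1500 nM.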

Compound 4, half-maximal inhibitory concentration: 49 nM
Compound 4: the middle estimate sits 2.0-fold (0.31 log units) above what was measured, and the stated range covers the measured number.
By their numbers in this assay, from the lowest: compounds 3 and 2 (each within the scatter of the next); then compound 4. At a limit, above all of these: compound 1.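

In this assay, hydrogen in place of trifluoromethyl on this aromatic carbon gives an at least 200-fold lower number from compound 1 to compound 4 (2.30 log units; beyond the scatter). That step is open on one side, as compound 1 gives a limit of the assay and not a number: the limit of > 10000 nM in this assay, at which 1 of the 4 values shown sits. Among the compounds shown here, compounds 1 and 4 form the first pair here that differs in one place, and both keep the pyridine and the cyclopropyl, so the gap between a limit and a measured number goes with the change from trifluoromethyl to hydrogen on this carbon of the shared core.

The pair does not settle how other groups read at this carbon, such as chlorine, methyl, methoxy or a nitrile, and so leaves open whether only trifluoromethyl gives such a large step or whether other groups there would do the same. Going by these compounds, how far the true number for compound 1 lies past its limit also remains unknown, as does whether the same change gives a step of similar size with ethyl or a longer chain in place of the cyclopropyl.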